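The source may hold more compounds than are shown below. What is called first, only, known or untested is meant among the compounds shown, and "the series" means these compounds.

In a functional assay on HOS cells (Homo sapiens) for antiproliferative activity, with a stated time of 72 h (a lower number here means a stronger inhibitor, a higher number a weaker inhibitor), compound 1 `OC[C@H]1O[C@@H](n2cnc3c(NCc4ccc(Cl)cc4Cl)ncnc32)[C@H](O)[C@@H]1O` gives > 166000 nM, which is a limit of the assay and not a number. Compound 2 `COc1cc(CNc2ncnc3c2ncn3[C@@H]2O[C@H](CO)[C@@H](O)[C@H]2O)cc(OC)c1` has the entry "not determined" (no result reported), so it has no number of its own. Compound 3 `OC[C@H]1O[C@@H](n2cnc3c(NCc4ccc(F)cc4F)ncnc32)[C@H](O)[C@@H]1O` carries 2,4-difluorophenyl in place of 3,5-dimethoxyphenyl on a saturated chain carbon bound to a nitrogen on an aromatic ring. Within the data shown here, with no number to step from, the only guide is compound 1 and (the limit of > 166000 nM in this assay, at which 1 of the 2 values shown sits), so compound 3 is expected to be very weak in this assay, with no large step toward stronger inhibition. Compound 3 is estimated at 150000 nM, with an expected range of 40000 nM to 300000 nM.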

Compound 3, half-maximal inhibitory concentration: > 166000 nM
Compound 3 was reported as a limit; the forecaster's own chance of this, stated with the estimate: 70%; at least 1.1-fold (0.04 log units) between middle value and limit.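

Compound 1 and compound 3 each end at a limit of this assay and not at a number, so the step between them cannot be read. From the compounds shown here alone, whether 2,4-difluorophenyl and 2,4-dichlorophenyl differ at all stays open, as does where compound 2 stands.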